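The source may report more compounds than this note shows. Statements on the series, on what has been measured and on what is new or still open speak of the compounds shown alone.

Values measured in a functional assay on HeLa cells (Homo sapiens) for cytotoxicity, read by MTT assay, with a stated time of 24 h; a lower number here means a stronger inhibitor, a higher number a weaker inhibitor:
- compound 1 `COc1cc(/C=C2\CN(C)C/C(=C\c3ccc(F)cc3)C2=O)cc(OC)c1`: 10200 nM
- compound 2 `COc1cc(/C=C2\CN(C)C/C(=C\c3ccc(Cl)cc3)C2=O)cc(OC)c1`: 11200 nM
- compound 3 `COc1cc(/C=C2\CN(C)C/C(=C\c3ccc(Br)cc3)C2=O)cc(OC)c1`: 5900 nM

In this assay, compound 3 gives 5900 nM, a value that cannot be separated from the other two: a 1.7-fold lower number from compound 1 to compound 3 (0.24 log units; within the scatter) and a 1.9-fold lower number from compound 2 to compound 3 (0.28 log units; within the scatter) both stay within the scatter.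

The next compound is compound 4 `COc1cc(/C=C2\CN(C)C/C(=C\c3ccc(Cl)c(Cl)c3)C2=O)cc(OC)c1`, which has 3,4-dichlorophenyl in place of 4-bromophenyl on a double-bonded chain carbon bound to a double-bonded ring carbon.

The nearest evidence is the halogen exchanges. These are a 1.1-fold higher number from compound 1 to compound 2 (0.04 log units; within the scatter), together with the two steps already given, and none goes beyond the scatter. Within the data shown here, no measured step shows what a second chlorine does, so this expectation remains uncertain. No step beyond the scatter is expected in this assay, and no direction can be assigned with confidence. The expected step is a 1.4-fold higher number from compound 3 to compound 4 (0.13 log units; within the scatter). For compound 4 the estimated value is 8000 nM, with an expected range of 3500 nM to 16000 nM.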

Compound 4, half-maximal inhibitory concentration: 6900 nM
Estimate against measurement, compound 4: 1.2-fold (0.06 log units) above; the measured number falls inside the stated range.
By their numbers in this assay, from the lowest: compounds 3, 4, 1 and 2 (each within the scatter of the next).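

In this assay, the first measured addition of a second halogen to this ring gives a 1.6-fold lower number from compound 2 to compound 4 (0.21 log units; within the scatter), so the second chlorine does not carry the number outside the scatter. The exchanges of a whole ring on the double-bonded chain carbon bound to a double-bonded ring carbon read the same way, with a 1.2-fold higher number from compound 3 to compound 4 (0.07 log units; within the scatter) and a 1.5-fold lower number from compound 1 to compound 4 (0.17 log units; within the scatter), so 3,4-dichlorophenyl cannot be separated from 4-fluorophenyl, 4-chlorophenyl or 4-bromophenyl at this position. No measurement shown bears on what lies behind these numbers.

Going by these compounds, whether an amine, a carboxylic acid or a longer chain in place of these halogens would give a step beyond the scatter remains open. All four compounds share the rest of the core, so the effect of a change elsewhere is open too.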